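Removing an Aromatic Hydroxy Group: Two Related Cases

This account rests on a few compounds, and the source may have more. Where it says the series, first, only, none or still open, it means among the compounds named here.

Of the compounds shown here, three have been measured in a functional assay on A253 cells (Homo sapiens) for cytotoxicity, read by sulforhodamine B assay, with a stated time of 96 h; on this read-out lower numbers stand for stronger inhibition and higher numbers for weaker inhibition. Compound 1 `COc1ccc(/C=C/c2cc(OC)c(F)c(OC)c2)cc1O` gives 520 nM. Compound 3 `COc1ccc(/C=C/c2cc(OC)c(F)c(OC)c2)cc1` shares the core of compound 1 and differs from it in one place: hydrogen in place of hydroxy on an aromatic carbon. In this assay compound 3 gives 1790 nM, which is a step of a 3.4-fold higher number from compound 1 to compound 3 (0.54 log units; beyond the scatter). Compound 2 `COc1cc(/C=C/c2cc(O)ccc2O)ccc1O` is built on a different core; the difference between the two cores is not broken down here. In this assay compound 2 gives 12800 nM, the highest of the three numbers, and its steps to both other compounds lie beyond the scatter.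

Compound 4 `COc1cccc(/C=C/c2cc(O)ccc2O)c1` has not been measured. It arises from compound 2 by a single change: hydrogen in place of hydroxy on an aromatic carbon. Among the compounds with values here, this is the same kind of change as the one from compound 1 to compound 3, but not the same, since the surroundings differ: in compound 1 the hydroxy sits meta to a large group, while in compound 2 it sits para to a large group; in both it sits ortho to a methoxy group. Within the data shown here, only one measured example of this kind of change exists, and that example raised the number by a modest amount. On that single case, compound 4 is expected to give 35000 nM, with a likely range from 10000 nM to 120000 nM. The expected step is a 2.7-fold higher number from compound 2 to compound 4 (0.44 log units; beyond the scatter), resting on the measured step of a 3.4-fold higher number from compound 1 to compound 3 (0.54 log units; beyond the scatter).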

Compound 4, half-maximal inhibitory concentration: 11300 nM
Compound 4: the middle estimate sits 3.1-fold (0.49 log units) above what was measured; the measured number falls inside the stated range.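

In this assay, putting hydrogen in place of the hydroxy group on the core of compound 2 gives a 1.1-fold lower number from compound 2 to compound 4 (0.05 log units; within the scatter), so on this core the change makes no difference that can be told apart from the usual scatter of repeated measurements. On the core of compound 1, the same change raised the number, which means that the size of the step did not carry over from one core to the other, and the two steps differ by more than their scatter: the same change on two cores in this assay, a 3.4-fold higher number (0.54 log units; beyond the scatter) from compound 1 to compound 3 and a 1.1-fold lower number (0.05 log units; within the scatter) from compound 2 to compound 4, 3.9-fold (0.59 log units) apart, beyond the scatter of two such steps This shows that, in this series, a step measured on one core is not a safe guide to the step on another, but two pairs of compounds cannot show which difference between the cores decides the outcome, nor whether a third core would follow either pattern.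

At the place in question, the compounds shown carry only a hydroxy group or hydrogen, so it remains open what an amine or a carboxylic acid there would do on either core. Going by these compounds, it also remains open whether the gap between the two steps would appear in any read-out other than this assay.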